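The source may hold more compounds than are shown below. What is called first, only, known or untested is meant among the compounds shown, and "the series" means these compounds.

Measured so far:
compound 1 `O=C(O)c1ccccc1NC(=O)C(C1CCCCC1)n1c(-c2ccc(Cl)cc2)nc2cc(F)c(F)cc21`: 320 nM
compound 2 `O=C(O)c1cccc(NC(=O)C(C2CCCCC2)n2c(-c3ccc(Cl)cc3)nc3cc(F)c(F)cc32)c1`: 1300 nM

Going by the values given here, compound 2 gives the highest number of the two in an assay on isolated protein for displacement of a labelled ligand from Bile acid receptor (Homo sapiens), read by scintillation proximity assay and radioligand binding; a lower number here means a stronger inhibitor, a higher number a weaker inhibitor; its nearest neighbour is compound 1, and the step of a 4.1-fold higher number from compound 1 to compound 2 (0.61 log units; beyond the scatter) is the only measured step. Compound 3 `O=C(O)Cc1ccc(NC(=O)C(C2CCCCC2)n2c(-c3ccc(Cl)cc3)nc3cc(F)c(F)cc32)cc1` has not yet been measured in this assay. It differs from compound 2 in one place: 4-(carboxymethyl)phenyl in place of 3-carboxyphenyl on an amide-type nitrogen.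

Among the compounds with values here, the one measured step bears on this change only loosely. It shows that moving the carboxylic acid from one position of the phenyl ring to another shifts the number in this assay by a modest, though real, amount. The change to compound 3 again moves the acid and also lengthens it by one carbon, so a shift of similar size in either direction is plausible, with no measured evidence to fix the sign. The step from compound 2 to compound 3 is therefore expected to be a 1.2-fold higher number from compound 2 to compound 3 (0.06 log units; within the scatter), that is, not clearly beyond the scatter. For compound 3 the expected number in this assay is 1500 nM, with a range from 450 nM to 5000 nM.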

Compound 3, half-maximal inhibitory concentration: 1400 nM
For compound 3 the middle estimate is 1.1-fold (0.03 log units) above the measured one; low and high end bracket the measured number.
By their numbers in this assay, from the lowest: compound 1; then compounds 2 and 3 (each within the scatter of the next).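

In this assay, 4-(carboxymethyl)phenyl in place of 3-carboxyphenyl on the amide-type nitrogen gives a 1.1-fold higher number from compound 2 to compound 3 (0.03 log units; within the scatter), so a group of 10 heavy atoms in place of one of 9 does not separate these two compounds. The 2-carboxyphenyl group of compound 1 now stands apart from two different groups rather than one: alongside a 4.1-fold higher number from compound 1 to compound 2 (0.61 log units; beyond the scatter) there is a 4.4-fold higher number from compound 1 to compound 3 (0.64 log units; beyond the scatter), and among these three compounds it alone gives a number beyond the scatter of the others. No measured information accounts for either the lower number of compound 1 or the lack of separation between compound 2 and compound 3.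

Compound 3 differs from compound 2 in both the place of the acid and the chain that carries it, and the compounds shown do not pull these two apart; 4-carboxyphenyl or 3-(carboxymethyl)phenyl on the same nitrogen would do so. Also open, from the compounds shown here alone, is whether the lower number of compound 1 would persist with 2-(carboxymethyl)phenyl, or with an ester or primary amide in place of the carboxylic acid.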